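A few compounds are considered here, and "the series" means these few. Any claim that something is new, unique, unknown or untested is made for them only; others in the source may bear on it.

Compounds measured in an assay on LtK cells with ATP-sensitive inward rectifier potassium channel 11 (Homo sapiens) as the target; on this read-out lower numbers stand for an effect already at smaller amounts and higher numbers for an effect only at larger amounts of compound:
compound 1 `O=C(CC1CCCC1)Nc1c(C(O)(C(F)(F)F)C(F)(F)F)ccc2ccccc12`: 81 nM
compound 2 `COCC(=O)Nc1c(C(O)(C(F)(F)F)C(F)(F)F)ccc2ccccc12`: 213 nM
compound 3 `O=C(CCc1ccccc1)Nc1c(C(O)(C(F)(F)F)C(F)(F)F)ccc2ccccc12`: 1750 nM

Compound 3 stands highest of the three numbers, nearest to compound 2 and furthest from compound 1, both steps beyond the scatter. Compound 4 `CC(C)OC(=O)Nc1c(C(O)(C(F)(F)F)C(F)(F)F)ccc2ccccc12` differs from compound 3 by isopropoxy in place of phenethyl on a carbonyl carbon. Within the data shown here, the steps that bear on it are a 22-fold higher number from compound 1 to compound 3 (1.33 log units; beyond the scatter) and an 8.2-fold higher number from compound 2 to compound 3 (0.91 log units; beyond the scatter), both on the same chain carbon bound to the carbonyl; the phenethyl chain of compound 3 carries the highest number, and compound 1 and compound 2, with their smaller groups, stand below it. Replacing phenethyl with the smaller isopropoxy is therefore expected to give a large step downward, a 12-fold lower number from compound 3 to compound 4 (1.07 log units; beyond the scatter). Compound 4 is estimated at 150 nM, within 50 nM to 500 nM.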

Compound 4, half-maximal effective concentration: 1160 nM
Beside the measured number, compound 4's estimate is 7.7-fold (0.89 log units) below it; measured number outside the range, above it.
By their numbers in this assay, from the lowest: compound 1; then compound 2; then compounds 4 and 3 (each within the scatter of the next).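

In this assay, the change from phenethyl to isopropoxy on the carbonyl carbon leaves the number within the scatter (a 1.5-fold lower number from compound 3 to compound 4 (0.18 log units; within the scatter)), so losing the six-membered aromatic ring does not by itself shift the result at this position. Smaller size alone does not order the series either, as isopropoxy still stands well apart from methoxymethyl (a 5.4-fold higher number from compound 2 to compound 4 (0.74 log units; beyond the scatter)) and cyclopentylmethyl (a 14-fold higher number from compound 1 to compound 4 (1.16 log units; beyond the scatter)). No measurement available here explains these differences.

On these data alone, whether the oxygen of isopropoxy matters stays open; an isobutyl group on the same carbonyl carbon would test this.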